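The source may report more compounds than this note shows. Statements on the series, on what has been measured and on what is new or still open speak of the compounds shown alone.

Measured so far in a functional assay for inhibition of sodium/hydrogen exchanger (Oryctolagus cuniculus); on this read-out higher numbers stand for weaker inhibition and lower numbers for stronger inhibition:
compound 1, `CCCc1cc(C)c(C(=O)N=C(N)N)cc1S(C)(=O)=O`, with compound 1 at 5.7 nM
compound 2, `Cc1cc(OC2CCCCC2)c(S(C)(=O)=O)cc1C(=O)N=C(N)N`, with compound 2 at 37 nM

For the measured compounds named here, compound 2 gives the higher of the two numbers; the only measured step, a 6.5-fold higher number from compound 1 to compound 2 (0.81 log units; beyond the scatter), separates it from compound 1. Compound 3, `Cc1cc(Oc2ccc(Cl)cc2)c(S(C)(=O)=O)cc1C(=O)N=C(N)N`, differs from compound 2 by 4-chlorophenyl in place of cyclohexyl on an oxygen on an aromatic ring. No measured step exchanges a saturated ring for an aromatic one on an ether oxygen, so the one step shown bears only loosely here: it indicates that a change at this position can move the number beyond the scatter, but not in which direction for this exchange. Compound 3 is therefore expected to stay near compound 2, at about 40 nM, within 10 nM to 160 nM. That estimate means a 1.1-fold higher number from compound 2 to compound 3 (0.03 log units; within the scatter), a step not expected to exceed the scatter.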

Compound 3, half-maximal inhibitory concentration: 13 nM
Compound 3: middle estimate off by 3.1-fold (0.49 log units), on the high side; measured number inside the range.
By their numbers in this assay, from the lowest: compound 1; then compound 3; then compound 2.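

In this assay, 4-chlorophenyl in place of cyclohexyl on the oxygen gives a 2.8-fold lower number from compound 2 to compound 3 (0.45 log units; beyond the scatter), so the number at this position depends on the group carried by the oxygen and not only on the oxygen itself. Propyl still holds the lower number, as 4-chlorophenoxy in its place gives a 2.3-fold higher number from compound 1 to compound 3 (0.36 log units; beyond the scatter). Nothing shown accounts for either step.

A plain phenoxy would separate the share of the chlorine from that of the aromatic ring. As far as these compounds go, how an amine on the same aromatic carbon would compare stays open.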